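Benzyl ring substitution alongside a constant amine

The source may hold more compounds than are shown below. What is called first, only, known or untested is meant among the compounds shown, and "the series" means these compounds.

Three compounds share the core of compound 1 `NC(=O)C1CCN(c2nc(-c3ccccn3)nc3c2CN(Cc2ccccc2)CC3)CC1` and differ only in the amine attached on an aromatic carbon. In an assay on FRT cells with Cystic fibrosis transmembrane conductance regulator variant F508del (Homo sapiens) as the target, read by fluorescence, with a stated time of 25 min (a lower number here means that less compound is needed, a higher number that more compound is needed for the effect), compound 1 gives 1400 nM. Compound 2 `NC(=O)CN1CCN(c2nc(-c3ccccn3)nc3c2CN(Cc2ccccc2)CC3)CC1` gives 2800 nM in this assay, and compound 3 `CN(C)CCN1CCN(c2nc(-c3ccccn3)nc3c2CN(Cc2ccccc2)CC3)CC1` gives 1500 nM. The steps of a 2.0-fold higher number from compound 1 to compound 2 (0.30 log units; within the scatter), a 1.1-fold higher number from compound 1 to compound 3 (0.03 log units; within the scatter) and a 1.9-fold lower number from compound 2 to compound 3 (0.27 log units; within the scatter) all stay within the scatter, so the three amines cannot be told apart on these numbers. Compound 3 sits alongside compound 1 and apart from compound 2 only within the scatter.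

Compound 4 `CC(C)c1ccc(CN2CCc3nc(-c4ccccn4)nc(N4CCN(CCN(C)C)CC4)c3C2)cc1` keeps the amine of compound 3 and alters the benzyl group: isopropyl in place of hydrogen on an aromatic carbon. For the measured compounds named here, none of the measured steps touches the benzyl ring; all three vary the amine only, so they give no direct guide to this change. Going by the values given here, with no comparable step in hand, the expectation is a change no larger than the scatter, no change at the digits printed from compound 3 to compound 4 (within the scatter). Compound 4 is therefore estimated at 1500 nM in this assay, with a range from 500 nM to 4500 nM.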

Compound 4, half-maximal effective concentration: 300 nM
Compound 4: middle estimate off by 5.0-fold (0.70 log units), on the high side; measured number below the stated range.
By their numbers in this assay, from the lowest: compound 4; then compounds 1, 3 and 2 (each within the scatter of the next).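

For the compounds shown here, the benzyl ring is the first place where a single change moves the number in this assay beyond the scatter: with the amine of compound 3 held constant, isopropyl in place of hydrogen on an aromatic carbon, para to a large group, gives a 5.0-fold lower number from compound 3 to compound 4 (0.70 log units; beyond the scatter). The amines of compounds 1, 2 and 3 all stayed within the scatter of each other, so the series shows a measurable response at this ring that the amine changes did not show. Nothing at hand bears on the reason for this step.

Open, on these data alone, is how this place on the ring responds to other groups, such as methyl, tert-butyl, methoxy or chlorine. Also open, as far as these compounds go, is whether 4-isopropylbenzyl gives a similar step alongside the amines of compound 1 and compound 2.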